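Amide nitrogen replacement in the triazole thioacetamide series

The source may hold more compounds than are shown below. What is called first, only, known or untested is meant among the compounds shown, and "the series" means these compounds.

Compound 1 `Cc1occc1-c1nnc(SCC(=O)Nc2ccc(F)cc2)n1Cc1ccco1` marks the weak end of the measured pair in a functional assay on CHO cells for antagonist activity at Orexin/Hypocretin receptor type 1 (Homo sapiens), read by FLIPR and calcium flux; on this read-out higher numbers stand for weaker inhibition and lower numbers for stronger inhibition: in this assay compound 1 gives > 15800 nM, which is a limit of the assay and not a number. Compound 2 `CC(=O)c1ccc(NC(=O)CSc2nnc(-c3ccoc3C)n2Cc2ccco2)cc1` carries acetyl in place of fluoro on an aromatic carbon; in this assay compound 2 gives 2510 nM. For the measured compounds named here, the single measured step, an at least 6.2-fold lower number from compound 1 to compound 2 (0.79 log units; beyond the scatter), is only a lower bound on its size because of the limit of > 15800 nM in this assay, at which 1 of the 2 values shown sits, for compound 1.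

Compound 3 `Cc1occc1-c1nnc(SCC(=O)NN2CCc3ccccc32)n1Cc1ccco1` differs from compound 1 by 2,3-dihydro-1H-indol-1-yl in place of 4-fluorophenyl on an amide-type nitrogen. Going by the values given here, no measured step touches the amide nitrogen itself; the one known step swaps a substituent on the aryl ring and leaves the ring in place. With compound 1 at the limit, the measured data neither fix a direction nor a size for the new step, and the expectation stays close to where compound 1 sits, with a wide range. Compound 3 is therefore estimated at 12000 nM, within 2500 nM to 50000 nM. This corresponds to an expected step of an at least 1.3-fold lower number from compound 1 to compound 3 (0.11 log units; that floor lies within the scatter).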

Compound 3, inhibition constant: > 15800 nM
Compound 3: no number, only a limit; the forecaster's own chance of this, stated with the estimate: 50%; at least 1.3-fold (0.11 log units) between middle value and limit.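

In this assay compound 3 gives > 15800 nM, which is a limit of the assay and not a number. Measured against the 4-acetylphenyl group, the 2,3-dihydro-1H-indol-1-yl group on the amide-type nitrogen gives an at least 6.2-fold higher number from compound 2 to compound 3 (0.79 log units; beyond the scatter), so this place responds not only to a substituent on the aryl ring but also to replacement of the whole group, and of the three groups shown only 4-acetylphenyl gives a number. The step from the 4-fluorophenyl group to the 2,3-dihydro-1H-indol-1-yl group cannot be read, because both of its ends rest on a limit: the limit of > 15800 nM in this assay, at which 2 of the 3 values shown sit.

Open, as far as these compounds go, is whether a nitrile or a carboxylic acid in place of the acetyl on the aromatic carbon would give a lower number than compound 2 or fall back to a limit. Also open, from the compounds shown here alone, is whether an amine such as piperidin-1-yl on the amide-type nitrogen, or an acetyl carried on the 2,3-dihydro-1H-indol-1-yl group, would give a number in this assay.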